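Lengthening the hydroxycarbamoyl chain of compound 3

The compounds below may be only part of what the source reports. "The series", "measured", "known", "first", "only" and "open" are said of these compounds alone.

Compound 3 (`CCOc1cc(C(C)(C)C)ccc1C1=NC(c2ccc(Cl)cc2)C(c2ccc(Cl)cc2)N1C(=O)N1CCN(CCCCC(=O)NO)CC1`) gives 12900 nM in a functional assay on NCI-H1299 cells (Homo sapiens) for antiproliferative activity, read by CCK-8 assay, with a stated time of 72 h (a higher number here means a weaker inhibitor, a lower number a stronger inhibitor), and lies within the scatter of both compound 1 (`CCOc1cc(C(C)(C)C)ccc1C1=NC(c2ccc(Cl)cc2)C(c2ccc(Cl)cc2)N1C(=O)NCCCCCCCC(=O)NO`) with 9060 nM and compound 2 (`CCOc1cc(C(C)(C)C)ccc1C1=NC(c2ccc(Cl)cc2)C(c2ccc(Cl)cc2)N1C(=O)NCCCCCCC(=O)Nc1ccccc1N`) with 17500 nM in the same read-out. The change to compound 4 (`CCOc1cc(C(C)(C)C)ccc1C1=NC(c2ccc(Cl)cc2)C(c2ccc(Cl)cc2)N1C(=O)N1CCN(CCCCCCCC(=O)NO)CC1`) is 3-(hydroxycarbamoyl)propyl in place of hydroxycarbamoyl on a saturated chain carbon, four bonds along the chain from an amine nitrogen in a ring on a saturated chain carbon, four bonds along the chain from an amine nitrogen in a ring. Among the compounds with values here, no measured step lengthens a chain. The only one is a 1.9-fold higher number from compound 1 to compound 2 (0.29 log units; within the scatter) and it exchanges the end group, so it bears on this change only indirectly. In this assay the estimate is a 1.4-fold lower number from compound 3 to compound 4 (0.16 log units; within the scatter) and no step beyond the scatter is expected. Compound 4 is expected at 9000 nM and the estimated range has 4000 nM as its lower and 18000 nM as its upper end.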

Compound 4, half-maximal inhibitory concentration: 7760 nM
The estimate for compound 4 lay 1.2-fold (0.06 log units) above the measured number, and the stated range covers the measured number.
By their numbers in this assay, from the lowest: compounds 4, 1, 3 and 2 (each within the scatter of the next, the first and the last beyond it).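

Within the data shown here, this is the first measured step that lengthens a chain: 3-(hydroxycarbamoyl)propyl in place of hydroxycarbamoyl, on a saturated chain carbon, four bonds along the chain from an amine nitrogen in a ring, gives a 1.7-fold lower number from compound 3 to compound 4 (0.22 log units; within the scatter) in this assay. The added length at this position therefore does not separate the two compounds in this read-out. No data bear on the reason for this result.

Still open, going by these compounds, is whether a longer chain at this position would give a step beyond the scatter. A carboxylic acid in place of the hydroxycarbamoyl end is likewise untested by the compounds shown here.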